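This account rests on a few compounds, and the source may have more. Where it says the series, first, only, none or still open, it means among the compounds named here.

Working notes on the series in a functional assay on HEK293 cells with D(4) dopamine receptor (Homo sapiens) as the target, read by FLIPR; on this read-out higher numbers stand for an effect only at larger amounts of compound and lower numbers for an effect already at smaller amounts. Compound 1 `O/N=C(\CCN1CCN(c2ccccn2)CC1)c1ccc(Cl)cc1` gives 475 nM. Compound 2 `CO/N=C(\CCN1CCN(c2ccccn2)CC1)c1ccc(Cl)cc1`, in which a methyl replaces the hydrogen on the oxygen, gives 37.6 nM. Going by the values given here, the single comparison available is a 13-fold lower number from compound 1 to compound 2 (1.10 log units; beyond the scatter), a change confined to the oxime oxygen. Among the compounds with values here, compound 2 therefore stands at the lowest of the two numbers, with compound 1 the only neighbour and that one beyond the scatter.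

Compound 3 `CO/N=C(\CCN1CCN(c2ccccn2)CC1)c1ccc(Cl)c(Cl)c1` is the next pairing. It differs from compound 2 by chloro in place of hydrogen on an aromatic carbon, which read one bond further out is 4-chlorophenyl to 3,4-dichlorophenyl. Within the data shown here, neither measured compound varies at the aromatic ring, so no measured step bears on this change; the one step known concerns the oxygen substituent and says nothing about a second chloro. With no guide from the data, the expectation is a step of no clear direction and of a size that may stay within the scatter. The estimate for compound 3 is 30 nM, with a range of 8 nM to 120 nM. The expected step is a 1.3-fold lower number from compound 2 to compound 3 (0.10 log units; within the scatter).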

Compound 3, half-maximal effective concentration: 542 nM
Compound 3: the middle estimate sits 18-fold (1.26 log units) below what was measured; measured number outside the range, above it.
By their numbers in this assay, from the lowest: compound 2; then compounds 1 and 3 (each within the scatter of the next).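

The aromatic ring is not a silent part of this series: in this assay, chloro in place of hydrogen on an aromatic carbon, ortho to a chloro group and meta to a large group, gives a 14-fold higher number from compound 2 to compound 3 (1.16 log units; beyond the scatter) on the O-methyl oxime of compound 2. The earlier step at the oxime oxygen, a 13-fold lower number from compound 1 to compound 2 (1.10 log units; beyond the scatter), is also large but runs the opposite way, so in these two pairs a change at the ring counts for as much as a change at the oxygen. Going by these compounds alone, a single added heavy atom is enough for this, since the change from 4-chlorophenyl to 3,4-dichlorophenyl is the only difference between compound 2 and compound 3, and no measurement at hand accounts for the size of the step.

Open, as far as these compounds go, is whether the higher number follows from chloro itself or from any group at this place, as a fluoro or a methoxy group there would show. Also open, from the compounds shown here alone, is whether the same step appears with the free oxime hydrogen of compound 1, or with a longer chain such as ethyl on the oxygen.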